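Swapping a furan for a pyridine on a shared core

The compounds below may be only part of what the source reports. "The series", "measured", "known", "first", "only" and "open" are said of these compounds alone.

Compound 1 `c1ccc(-c2ccnc(Nc3cccc(OCCn4ccnc4)c3)n2)nc1`: 400 nM
Compound 2 `CC(=O)Nc1cccc(Nc2nccc(-c3ccccn3)n2)c1`: 300 nM
Compound 3 `Cc1cccc(Nc2nccc(-c3ccc(C)o3)n2)c1`: 2000 nM

All three were tested in a functional assay for inhibition, with Homo sapiens as the target; on this read-out lower numbers stand for stronger inhibition and higher numbers for weaker inhibition. Among the compounds with values here, compound 3 gives the highest number of the three, beyond the scatter from both compound 1 and compound 2, which stand within the scatter of each other; the one measured step, a 1.3-fold lower number from compound 1 to compound 2 (0.12 log units; within the scatter), changes a substituent on the anilino ring only.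

Compound 4 `Cc1cccc(Nc2nccc(-c3ccccn3)n2)c1` differs from compound 3 in a single place: pyridin-2-yl in place of 5-methylfuran-2-yl on an aromatic carbon. Within the data shown here, no measured step changes this ring, so the comparison rests on what the values show: compound 1 and compound 2, which carry pyridin-2-yl at the same place, both give markedly lower numbers than compound 3 with 5-methylfuran-2-yl, though they also differ from compound 3 on the anilino ring. A drop beyond the scatter is therefore expected, roughly a 5.0-fold lower number from compound 3 to compound 4 (0.70 log units; beyond the scatter). Compound 4 is estimated at 400 nM, with a range of 150 nM to 1200 nM.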

Compound 4, half-maximal inhibitory concentration: 700 nM
Compound 4: middle estimate off by 1.8-fold (0.24 log units), on the low side; the range from low to high includes it.
By their numbers in this assay, from the lowest: compounds 2, 1 and 4 (each within the scatter of the next, the first and the last beyond it); then compound 3.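

Read on its own, the ring change is a modest one in this assay: pyridin-2-yl in place of 5-methylfuran-2-yl gives a 2.9-fold lower number from compound 3 to compound 4 (0.46 log units; beyond the scatter) on an otherwise identical structure. With pyridin-2-yl held fixed, the anilino ring now shows two further steps, as methyl in place of acetamido gives a 2.3-fold higher number from compound 2 to compound 4 (0.37 log units; beyond the scatter) and methyl in place of 2-(1H-imidazol-1-yl)ethoxy gives a 1.8-fold higher number from compound 1 to compound 4 (0.24 log units; within the scatter). Nothing measured here explains any of these steps.

The step from compound 3 to compound 4 swaps the ring and removes the furan's methyl together, so it cannot say which of the two matters; a plain furan-2-yl or a 5-methylpyridin-2-yl group would separate them. As far as these compounds go, whether a phenyl or pyridin-3-yl ring at this position would match pyridin-2-yl also remains open.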